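Halogen to methyl exchange on the fused ring

This account rests on a few compounds, and the source may have more. Where it says the series, first, only, none or still open, it means among the compounds named here.

Among the compounds with values here, compound 3 `O=C(O)CC(Cc1nc2cc(Br)ccc2[nH]1)c1ccc(Cl)cc1` gives 80% in an assay on isolated protein for inhibition of protein kinase C zeta type (Homo sapiens), read by 33P incorporation, tested at 200 uM (on this read-out lower numbers stand for a weaker effect and higher numbers for a stronger effect at the one concentration tested), and stands highest of the three numbers measured so far. Nearest is compound 1 `O=C(O)CC(Cc1nc2cc(Cl)ccc2[nH]1)c1ccc(Cl)cc1`, which in this assay gives 70%; the step of a number 10 percentage points higher from compound 1 to compound 3 (within the scatter) is within the scatter. Furthest is compound 2 `O=C(O)CC(Cc1nc2cc(F)ccc2[nH]1)c1ccc(Cl)cc1`, which in this assay gives 30%, and the step of a number 50 percentage points higher from compound 2 to compound 3 (beyond the scatter) lies beyond the scatter, as does a number 40 percentage points lower from compound 1 to compound 2 (beyond the scatter).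

Compound 4 `Cc1ccc2[nH]c(CC(CC(=O)O)c3ccc(Cl)cc3)nc2c1` differs from compound 3 by methyl in place of bromo on an aromatic carbon. The three measured steps all exchange one halogen for another on the same aromatic carbon: bromo and chloro give numbers within the scatter of each other, whereas fluoro gives a far lower number. Within the data shown here, no measured step brings in methyl, so the only guide is that the read-out answers strongly to what stands on this aromatic carbon and that two of the three measured groups gave high numbers. The expected step of a number 25 percentage points lower from compound 3 to compound 4 (beyond the scatter) is therefore downward, of uncertain size, possibly beyond the scatter. Compound 4 is expected to give about 55%, estimated within 25% to 80%.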

Compound 4, a percentage reported as inhibition, at one concentration (the size of the read-out at that concentration, not a potency): 0%
Compound 4: the middle estimate sits 55 percentage points above what was measured, outside the stated range (below it).
By their numbers in this assay, from the lowest: compound 4; then compound 2; then compounds 1 and 3 (each within the scatter of the next).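

Within the data shown here, on this aromatic carbon, methyl is the first group that is not a halogen, and in this assay it stands apart from all three halogens: a number 80 percentage points lower from compound 3 to compound 4 (beyond the scatter) and a number 70 percentage points lower from compound 1 to compound 4 (beyond the scatter) and also a number 30 percentage points lower from compound 2 to compound 4 (beyond the scatter). Fluoro therefore no longer marks the low end of the series, and methyl and bromo, which have the same counts of heavy atoms, hydrogen-bond donors and hydrogen-bond acceptors, show that these counts do not separate high numbers from low numbers at this position. Nothing measured on these compounds accounts for the loss on going to methyl.

Open, going by these compounds, is whether the loss belongs to methyl alone or extends to other groups that are not halogens, such as methoxy, trifluoromethyl, nitrile or an amine. Also open, on these data alone, is how the unsubstituted aromatic carbon, bearing only hydrogen, would compare with the halogens and methyl.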